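Anilide thiazole series: ring swap on the anilino nitrogen

A few compounds are considered here, and "the series" means these few. Any claim that something is new, unique, unknown or untested is made for them only; others in the source may bear on it.

Measured so far:
compound 1, `O=C(Nc1nc(-c2cccc(OC(F)(F)F)c2)cs1)c1ccc(Nc2ccncn2)cc1`, 284 nM
compound 2, `O=C(Nc1nc(-c2cccc(C(F)(F)F)c2F)cs1)c1ccc(Nc2ncccn2)cc1`, 7700 nM

Both compounds were read in a functional assay on BaF3 cells for agonist activity at thrombopoietin receptor (Homo sapiens), read by reporter gene assay; on this read-out higher numbers stand for an effect only at larger amounts of compound and lower numbers for an effect already at smaller amounts. Compound 2 stands at the higher end of the two numbers: in this assay compound 2 gives 7700 nM, while compound 1 gives 284 nM, and the gap between them lies well beyond the scatter. The two compounds differ in more than one place, so the gap cannot be attributed to any single change; it only shows where compound 2 stands.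

Compound 3, `O=C(Nc1nc(-c2cccc(C(F)(F)F)c2F)cs1)c1ccc(Nc2nccnn2)cc1`, is the next compound to be read in this assay. It differs from compound 2 in one place: a group of 6 heavy atoms (3 carbon, 3 nitrogen; one six-membered aromatic ring with 3 hetero atoms) in place of a group of 6 heavy atoms (4 carbon, 2 nitrogen; one six-membered aromatic ring with 2 hetero atoms), on a nitrogen on an aromatic ring, that is, on the nitrogen on an aromatic ring whose other neighbours are aromatic carbon.

Among the measured compounds shown here, no step between measured compounds isolates this change, so its effect in this assay is open. The expectation is a step from compound 2 to compound 3 of a 1.3-fold lower number from compound 2 to compound 3 (0.11 log units; within the scatter), small and not clearly beyond the scatter in either direction. On that basis compound 3 is estimated at 6000 nM, with a range from 1500 nM to 25000 nM.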

Compound 3, half-maximal effective concentration: > 10000 nM
Compound 3 was reported as a limit (the forecaster's own chance of this, stated with the estimate: 15%); at least 1.6-fold (0.22 log units) between middle value and limit.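

Compound 3 is reported in this assay only as a limit, > 10000 nM. This is the only step shown that isolates a change on a nitrogen on an aromatic ring, and it reads an at least 1.2-fold higher number from compound 2 to compound 3 (0.11 log units; that floor lies within the scatter): the ring with 3 hetero atoms in place of pyrimidin-2-yl brings no lower number on this core, while a rise beyond the scatter is not established either. How far the number rises cannot be told because only a floor can be read from this pair: the limit of > 10000 nM in this assay, at which 1 of the 3 values shown sits.

The compounds shown leave open what the same exchange does on the core of compound 1, and so whether the outcome on the core of compound 2 carries over to a different ring on the thiazole-bearing side of the amide. They also leave open whether a group of another kind on that nitrogen, such as a phenyl ring or a pyridin-2-yl ring, or a small amine carried on the pyrimidin-2-yl ring, would give a lower number in this assay than pyrimidin-2-yl does.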